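This account rests on a few compounds, and the source may have more. Where it says the series, first, only, none or still open, it means among the compounds named here.

In a functional assay on MCF7 cells (Homo sapiens) for antiproliferative activity, read by sulforhodamine B assay, with a stated time of 48 h (a lower number here means a stronger inhibitor, a higher number a weaker inhibitor), compound 1 `CCN1CCN(c2ccc(S(=O)(=O)Oc3cccc(F)c3)cc2)C1=O` returns only a limit, > 100000 nM, and not a number. Among the compounds with values here, compound 2 `CCCCN1CCN(c2ccc(S(=O)(=O)Oc3ccccc3OC)cc2)C1=O` gives 3800 nM in this assay, which makes it the only plain number in this set. Compound 3 `CCCCN1CCN(c2ccc(S(=O)(=O)Oc3cccc(F)c3)cc2)C1=O` is reached from compound 2 by a single change: 3-fluorophenyl in place of 2-methoxyphenyl on an oxygen. Within the data shown here, no measured step joins these two compounds. Compound 1, which carries the same 3-fluorophenyl on that oxygen, sits at the limit (the limit of > 100000 nM in this assay, at which 1 of the 2 values shown sits). Compound 3 is therefore expected to be weaker than compound 2, with a step of a 7.9-fold higher number from compound 2 to compound 3 (0.90 log units; beyond the scatter). The estimate for compound 3 is 30000 nM, within 6000 nM to 100000 nM.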

Compound 3, half-maximal inhibitory concentration: 310 nM
Beside the measured number, compound 3's estimate is 97-fold (1.99 log units) above it; the measured number lies below the stated range.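

The 3-fluorophenyl on the oxygen carrying the sulfonyl sulfur does not itself cost activity in this assay: with the butyl chain kept, the change gives a 12-fold lower number from compound 2 to compound 3 (1.09 log units; beyond the scatter). With the 3-fluorophenyl held fixed, ethyl in place of hydrogen on the saturated chain carbon gives an at least 320-fold lower number from compound 1 to compound 3 (2.50 log units; beyond the scatter), so the chain, not this aryl group, separates those two. The value of compound 1 is a limit and not a number: the limit of > 100000 nM in this assay, at which 1 of the 3 values shown sits.

The compounds shown leave open whether 3-chlorophenyl or plain phenyl on this oxygen would match 3-fluorophenyl. They also leave open whether a hexyl chain would carry the gain further.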